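Bromo added to the core of compound 2

The compounds below may be only part of what the source reports. "The series", "measured", "known", "first", "only" and "open" are said of these compounds alone.

The three measured compounds share a carbonyl-linked sulfonamide on a fused two-ring core and differ in the arene on the sulfonyl group and in a substituent on that core. Compound 1 `O=C(NS(=O)(=O)c1cccc([N+](=O)[O-])c1)n1ccc2cccnc21`, compound 2 `O=C(NS(=O)(=O)c1ccc2ccccc2c1)n1ccc2cccnc21` and compound 3 `O=C(NS(=O)(=O)c1ccccc1)n1ccc2cc(Br)cnc21` were each tested in a functional assay on HT-29 cells (Homo sapiens) for antiproliferative activity, read by MTT assay, with a stated time of 24 h, tested at 10 uM; a lower number here means less inhibition, a higher number more inhibition at the concentration tested (going by the name of the read-out). Compound 1 gives 18.9%, compound 2 gives 16.2% and compound 3 gives 14.6%, so compound 2 stands second highest of the three numbers, though its distances to compound 3 and to compound 1 both lie within the usual scatter of this assay, and no ordering among the three can be read from them.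

Compound 4 `O=C(NS(=O)(=O)c1ccc2ccccc2c1)n1ccc2cc(Br)cnc21` is not yet measured. It differs from compound 2 by bromo in place of hydrogen on an aromatic carbon. Since compound 3 carries the same bromo and gives 14.6%, a number indistinguishable from that of compound 2, the step from compound 2 to compound 4 is expected to be no larger than the scatter, in no particular direction, as a number 0.2 percentage points lower from compound 2 to compound 4 (within the scatter). Compound 4 is therefore estimated at 16%, within a range from 5% to 27%.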

Compound 4, a percentage reported as inhibition, at one concentration (the size of the read-out at that concentration, not a potency): 60.1%
The estimate for compound 4 lay 44.1 percentage points below the measured number, and the stated range ends below it.
By their numbers in this assay, from the lowest: compounds 3, 2 and 1 (each within the scatter of the next); then compound 4.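

In this assay bromo in place of hydrogen on an aromatic carbon, two atoms from the ring nitrogen, gives a number 43.9 percentage points higher from compound 2 to compound 4 (beyond the scatter) and so shows that this position of the core can respond strongly to a single heavy atom. The bromo alone does not settle the number: compound 3 carries the same bromo with a different arene on the sulfonyl group and gives 14.6% while compound 4 gives 60.1% in this read-out. The large number therefore appears here only when the bromo is paired with the arene of compound 2.

On these data alone, it remains open whether a chloro, a methoxy or an amine at the same position would act like bromo, and whether bromo would raise the number with the arene of compound 1. Nothing shown here explains the size of this step.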